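The compounds below may be only part of what the source reports. "The series", "measured", "known", "first", "only" and "open" are said of these compounds alone.

Working notes on the series. The shared core is carried by compound 1 `CCCCOc1ccc2[nH]c(-c3ccc(OC)cc3)c(C3=C(Br)C(=O)NC3=O)c2c1` and compound 2 `CCCCCc1ccc2[nH]c(-c3ccc(OC)cc3)c(C3=C(Br)C(=O)NC3=O)c2c1`. In a physicochemical assay for lipophilicity (a lower number here means a more polar compound, a higher number a more lipophilic compound), compound 1 gives 3.43, and in this assay compound 2 gives 4.1. Among the compounds with values here, compound 1 thus stands lowest of the two numbers so far, with compound 2 as its only neighbour. Within the data shown here, the one measured step is a number 0.67 log units higher from compound 1 to compound 2 (beyond the scatter); it concerns the chain on the core and not the group that changes here.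

Compound 3 `CCCCOc1ccc2[nH]c(-c3cccc(OC)c3)c(C3=C(Br)C(=O)NC3=O)c2c1` is still to be measured. The change from compound 1 to compound 3 is 3-methoxyphenyl in place of 4-methoxyphenyl on an aromatic carbon: the same atoms, joined differently. Among the measured compounds shown here, no measured step touches this group, so the step from compound 1 to compound 2 does not bear on it and gives no direction. For the measured compounds named here, with the atom count unchanged and no comparable step to draw on, a step no larger than the scatter is expected in this assay. The estimated value for compound 3 in this assay is 3.4, expected to lie between 3.1 and 3.7. The expected step of a number 0.03 log units lower from compound 1 to compound 3 (within the scatter) is therefore within the scatter.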

Compound 3, partition coefficient: 3.46
Beside the measured number, compound 3's estimate is 0.06 log units below it; measured number inside the range.
By their numbers in this assay, from the lowest: compounds 1 and 3 (each within the scatter of the next); then compound 2.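

In this assay, within the data shown here, the first measured step at the group on the aromatic carbon next to the ring nitrogen, 3-methoxyphenyl in place of 4-methoxyphenyl, is a number 0.03 log units higher from compound 1 to compound 3 (within the scatter) and so gives no separation between the two arrangements. Among these compounds, for this one pair, with the butoxy chain held constant and the same atoms joined differently, the read-out does not tell the two aryl groups apart, whereas the only step beyond the scatter so far remains a number 0.67 log units higher from compound 1 to compound 2 (beyond the scatter) at the chain on the core. Nothing measured in the series offers an explanation for this result.

The compounds shown leave open whether the same reading holds alongside the pentyl chain of compound 2, as 3-methoxyphenyl appears here only with butoxy. They also leave open how the number would respond if the methoxy on this phenyl ring gave way to a different group, such as an amine or a carboxylic acid, since both aryl groups compared here carry the same methoxy group.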